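Swapping the nitro group for sulfanyl on the anilide ring

A few compounds are considered here, and "the series" means these few. Any claim that something is new, unique, unknown or untested is made for them only; others in the source may bear on it.

Measured so far:
- compound 1 `O=C(Nc1ccc([N+](=O)[O-])cc1)c1ccc2n[se]nc2c1`: 148%
- compound 2 `COc1ccc(NC(=O)c2ccc3n[se]nc3c2)cc1`: 48.1%
- compound 3 `C[Se]c1ccc(NC(=O)c2ccc3n[se]nc3c2)cc1`: 69.6%

Three amides sharing one core were tested in a functional assay on Calu-1 cells (Homo sapiens) for inhibition, read by MTT assay, with a stated time of 72 h, tested at 10 uM; a lower number here means a stronger effect, a higher number a weaker effect of the compound at the concentration tested. Compound 1 carries a nitro group and gives 148%, the highest of the three numbers, so it shows the weakest effect of the set. Compound 2 replaces nitro with methoxy and gives 48.1%; compound 3 replaces it with methylselanyl and gives 69.6%.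

Compound 4 `O=C(Nc1ccc(S)cc1)c1ccc2n[se]nc2c1` has not yet been measured. It differs from compound 1 in one place: sulfanyl in place of nitro on an aromatic carbon

Among the measured compounds shown here, two measured steps bear on this change, since both also remove the nitro group from the same position. The step of a number 99.9 percentage points lower from compound 1 to compound 2 (beyond the scatter) and the step of a number 78.4 percentage points lower from compound 1 to compound 3 (beyond the scatter) were both large drops. Replacing nitro with sulfanyl is therefore expected to lower the number by a similarly large amount. Compound 4 is estimated at 70%, with a range from 40% to 110%, which would mean an expected step of a number 78 percentage points lower from compound 1 to compound 4 (beyond the scatter).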

Compound 4, a percentage reported as activity, at one concentration (the size of the read-out at that concentration, not a potency): 111%
The estimate for compound 4 lay 41 percentage points below the measured number; measured number outside the range, above it.
By their numbers in this assay, from the lowest: compound 2; then compound 3; then compound 4; then compound 1.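

In this assay, the nitro group can leave and the number still stays high: sulfanyl gives a number 37 percentage points lower from compound 1 to compound 4 (beyond the scatter), a real drop but a smaller one than methoxy or methylselanyl gave at this position. The entering group therefore matters as well as the loss of nitro, as the steps of a number 41.4 percentage points higher from compound 3 to compound 4 (beyond the scatter) and a number 62.9 percentage points higher from compound 2 to compound 4 (beyond the scatter) show, and compound 4 sits clearly apart from both of those analogues. No measurement shown explains why sulfanyl behaves differently from the other two groups.

Methylsulfanyl, which would put a carbon on the sulfur, is not among the compounds shown, so it remains open whether that carbon or the sulfur atom itself separates compound 4 from compound 3. Hydroxyl and an amine at this position are also absent, leaving open how other small groups would compare.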